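Compound 2 and a methylamino swap

This account rests on a few compounds, and the source may have more. Where it says the series, first, only, none or still open, it means among the compounds named here.

Measured so far in an ADME assay on HeLa cells (Homo sapiens) for cytotoxicity, read by crystal violet staining, with a stated time of 72 h; on this read-out lower numbers stand for higher toxicity in this test and higher numbers for lower toxicity in this test:
Compound 1 `CCOC(=O)c1cc(CCCOc2ccc(-c3noc(C(F)(F)F)n3)cc2)on1`: > 100000 nM
Compound 2 `Cc1cc(-c2noc(C(F)(F)F)n2)cc(C)c1OCCCc1cc(C(=O)OC(C)C)no1`: 17900 nM

Only one of these two results is an actual number. Compound 2 gives 17900 nM, so it has a measured half-maximal cytotoxic concentration. Compound 1 gives > 100000 nM, which is a limit of the assay and not a number. Among the compounds with values here, no pair of measured compounds differing in just one place is available, so there is no direct guide to the size of the next step.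

Compound 3 `CNC(=O)c1cc(CCCOc2c(C)cc(-c3noc(C(F)(F)F)n3)cc2C)on1` is reached from compound 2 by a single change, isopropoxycarbonyl to methylcarbamoyl: methylamino in place of isopropoxy on a carbonyl carbon. In words, methylamino takes the place of isopropoxy on a carbonyl carbon. The expectation here is a moderate move towards lower toxicity in this assay, although a result within the usual scatter would be no surprise. Compound 2, at 17900 nM, leaves room for such a rise. The estimated change is a 2.5-fold higher number from compound 2 to compound 3 (0.40 log units; beyond the scatter). For compound 3 the expected value is 45000 nM, with an estimated range of 15000 nM to 100000 nM.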

Compound 3, half-maximal cytotoxic concentration: > 100000 nM
Compound 3: only a limit was reported; the forecaster's own chance of this, stated with the estimate: 35%; middle value at least 2.2-fold (0.34 log units) away from the limit.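

Within the data shown here, replacing isopropoxy with methylamino on a carbonyl carbon gives the first direct reading of a single change: in this assay, the swap produces an at least 5.5-fold higher number from compound 2 to compound 3 (0.74 log units; beyond the scatter). Compound 3 gives only a limit of the assay and not a number, so the step has a lower bound but no known full size. This shows that the group on this carbonyl carbon can shift the result well beyond the usual scatter, although the top of the measurable range now restricts what can be read from this series: the limit of > 100000 nM in this assay, at which 2 of the 3 values shown sit.

The compounds shown leave open whether the rise depends on losing isopropoxy or on gaining methylamino, which is smaller and carries a hydrogen-bond donor, and they do not show how far compound 3 lies past its limit. Dimethylamino, ethylamino or a carboxylic acid on the same carbonyl carbon could help separate these possibilities, particularly if any of them gave an actual number rather than another limit.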